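The source may report more compounds than this note shows. Statements on the series, on what has been measured and on what is new or still open speak of the compounds shown alone.

Three compounds sharing one core have been run in an in vivo ADME assay on the whole organism (strain Mongrel) for pharmacokinetics, with Canis familiaris (Canis lupus familiaris) as the target; on this read-out higher numbers stand for fast clearance and lower numbers for slow clearance. Compound 1 `COc1ncc(C(=O)NC2(C(=O)N[C@H](C)c3ccc(-n4nc(Cl)c5ccccc54)cc3F)CC2)s1` gives 1.7 mL/min/kg. Compound 2 `C[C@@H](NC(=O)C1(NC(=O)c2ccc(Br)nc2)CC1)c1ccc(-n2nc(Cl)c3ccccc32)cc1F` gives 2.6 mL/min/kg. Compound 3 `C[C@@H](NC(=O)C1(NC(=O)c2cncc(Cl)c2)CC1)c1ccc(-n2nc(Cl)c3ccccc32)cc1F` gives 3.1 mL/min/kg, a number that sits within the scatter of both compound 1 and compound 2, as the steps of a 1.8-fold higher number from compound 1 to compound 3 (0.26 log units; within the scatter) and a 1.2-fold higher number from compound 2 to compound 3 (0.08 log units; within the scatter) show. Compound 4 `C[C@@H](NC(=O)C1(NC(=O)c2cncc(Br)c2)CC1)c1ccc(-n2nc(Cl)c3ccccc32)cc1F` differs from compound 3 only in this: bromo in place of chloro on an aromatic carbon. Among the measured compounds shown here, no measured step exchanges one halogen for another on the same ring; the nearest comparison, a 1.2-fold higher number from compound 2 to compound 3 (0.08 log units; within the scatter), changes both the halogen and its place and still stays within the scatter. Compound 4 is therefore expected to show a 1.1-fold higher number from compound 3 to compound 4 (0.03 log units; within the scatter), and its clearance is estimated at 3.3 mL/min/kg, within a range of 1.8 mL/min/kg to 6 mL/min/kg.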

Compound 4, clearance: 3.8 mL/min/kg
Beside the measured number, compound 4's estimate is 1.2-fold (0.06 log units) below it; low and high end bracket the measured number.
By their numbers in this assay, from the lowest: compounds 1, 2, 3 and 4 (each within the scatter of the next, the first and the last beyond it).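

In this assay, bromo in place of chloro on the 5-chloropyridin-3-yl group gives a 1.2-fold higher number from compound 3 to compound 4 (0.09 log units; within the scatter), so this direct halogen exchange does not separate the two compounds. Moving the bromo, with 5-bromopyridin-3-yl in place of 6-bromopyridin-3-yl, gives a 1.5-fold higher number from compound 2 to compound 4 (0.16 log units; within the scatter), which again does not separate them. Among the compounds shown here, with 5-bromopyridin-3-yl in place of 2-methoxy-1,3-thiazol-5-yl, the step is a 2.2-fold higher number from compound 1 to compound 4 (0.35 log units; beyond the scatter), a modest difference and the only step in this set beyond the scatter. Nothing available here explains these steps. From the compounds shown here alone, whether an amine or a carboxylic acid in place of the halogen would shift clearance remains open.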